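Swapping the aryl group on the saturated ring carbon

The compounds below may be only part of what the source reports. "The series", "measured", "known", "first", "only" and "open" are said of these compounds alone.

Measured compounds:
compound 1 `COc1cc(C2=NN(C(C)=O)C(c3c(Cl)cccc3Cl)O2)cc(OC)c1OC` with -1.4%
compound 2 `COc1cc(C2=NN(C(C)=O)C(c3cccc(OC)c3OC)O2)cc(OC)c1OC` with 3.8%
compound 3 `COc1ccc(C2OC(c3cc(OC)c(OC)c(OC)c3)=NN2C(C)=O)c(OC)c1` with 6.3%

All three were tested in a functional assay on BGC-823 cells (Homo sapiens) for antiproliferative activity, read by MTT assay, tested at 1 uM; a lower number here means a weaker effect, a higher number a stronger effect of the compound at the concentration tested. Compound 3 has the highest of the three numbers, but its lead is small: the step of a number 2.5 percentage points higher from compound 2 to compound 3 (within the scatter) and the step of a number 7.7 percentage points higher from compound 1 to compound 3 (within the scatter) are both within the scatter, so no ordering among compounds 1, 2 and 3 can be claimed.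

Compound 4 `COc1cc(C2=NN(C(C)=O)C(c3ccc(Cl)c(Cl)c3)O2)cc(OC)c1OC` is the next compound. Its change from compound 3 is 3,4-dichlorophenyl in place of 2,4-dimethoxyphenyl on a saturated ring carbon.

The measured steps that bear on this are the ones that exchange the aryl group at the same place: a number 7.7 percentage points higher from compound 1 to compound 3 (within the scatter), a number 5.2 percentage points higher from compound 1 to compound 2 (within the scatter) and a number 2.5 percentage points higher from compound 2 to compound 3 (within the scatter). Each of them stayed within the scatter, whether chlorine or methoxy groups were on the ring. Compound 4 therefore is expected to show no step beyond the scatter in this assay, with a number 4.3 percentage points lower from compound 3 to compound 4 (within the scatter) as the estimated step from compound 3. Compound 4 is thus estimated at 2%, expected to fall between -10% and 14%.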

Compound 4, a percentage reported as inhibition, at one concentration (the size of the read-out at that concentration, not a potency): -0.8%
Compound 4: the middle estimate sits 2.8 percentage points above what was measured, within the range that was stated.
By their numbers in this assay, from the lowest: compounds 1, 4, 2 and 3 (each within the scatter of the next).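

In this assay, bringing in 3,4-dichlorophenyl on the saturated ring carbon gives a number 7.1 percentage points lower from compound 3 to compound 4 (within the scatter), a number 4.6 percentage points lower from compound 2 to compound 4 (within the scatter) and a number 0.6 percentage points higher from compound 1 to compound 4 (within the scatter), so none of the four aryl groups now seen at this position stands apart from the others. Even exchanging 2,4-dimethoxyphenyl, which has hydrogen-bond acceptors, for 3,4-dichlorophenyl, which has none, stays within the scatter, and the two dichlorophenyl groups cannot be told apart. No independent measurement bears on this result.

As far as these compounds go, all four compounds carry a phenyl ring bearing chlorine or methoxy groups at this position and were read at a single concentration, so it stays open whether a higher concentration would separate them. Also open, from the compounds shown here alone, is whether an amine or a carboxylic acid on that ring, or a longer chain in its place, would produce a step beyond the scatter.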